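Added hydroxy on the aryl ring and cytotoxicity

This account rests on a few compounds, and the source may have more. Where it says the series, first, only, none or still open, it means among the compounds named here.

Measured compounds:
compound 1 `O=[N+]([O-])C1=NNc2ncnn2C1c1ccc(O)c(O)c1` > 1630000 nM
compound 2 `O=[N+]([O-])C1=CNc2nc(-c3ccco3)nn2C1c1ccc(O)cc1O` 119000 nM
compound 3 `O=[N+]([O-])C1=NNc2ncnn2C1c1ccc(O)c(O)c1O` 228000 nM

In an ADME assay on MDCK cells (Canis lupus familiaris) for cytotoxicity (on this read-out higher numbers stand for lower toxicity in this test and lower numbers for higher toxicity in this test), compound 1 gives only a limit, > 1630000 nM, and no number. Compound 3 gives 228000 nM, and the step of an at least 7.1-fold lower number from compound 1 to compound 3 (0.85 log units; beyond the scatter) rests on (the limit of > 1630000 nM in this assay, at which 1 of the 3 values shown sits). The change is hydroxy in place of hydrogen on an aromatic carbon. Compound 2 gives 119000 nM; the difference between its core and that of compound 1 is not broken down here, and its value and that of compound 3 lie within the scatter of each other.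

Compound 4 `O=[N+]([O-])C1=CNc2nc(-c3ccco3)nn2C1c1ccc(O)c(O)c1O` is not yet measured. It differs from compound 2 by hydroxy in place of hydrogen on an aromatic carbon, the same kind of change as from compound 1 to compound 3, though here the place is ortho to two hydroxy groups and meta to a large group. Because an at least 7.1-fold lower number from compound 1 to compound 3 (0.85 log units; beyond the scatter) went lower, compound 4 is expected to show a smaller step, a 3.0-fold lower number from compound 2 to compound 4 (0.47 log units; beyond the scatter), since compound 2 gave 119000 nM as a number. Compound 4 is estimated at 40000 nM, between 10000 nM and 130000 nM.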

Compound 4, half-maximal cytotoxic concentration: 317000 nM
Estimate against measurement, compound 4: 7.9-fold (0.90 log units) below; measured number outside the range, above it.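

In this assay, hydroxy in place of hydrogen on an aromatic carbon now goes with a 2.7-fold higher number from compound 2 to compound 4 (0.43 log units; beyond the scatter), so the change does not carry over in direction from the core of compound 1 to the core of compound 2: the same change on two cores in this assay, an at least 7.1-fold lower number (0.85 log units; beyond the scatter) from compound 1 to compound 3 and a 2.7-fold higher number (0.43 log units; beyond the scatter) from compound 2 to compound 4, at least 19-fold (1.27 log units) apart, beyond the scatter of two such steps

This does not show which difference between compound 1 and compound 2 lies behind the reversal, and two pairs cannot set a rule for the series. The earlier step is only a bound, since compound 1 gives a limit and not a number: the limit of > 1630000 nM in this assay, at which 1 of the 4 values shown sits.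

As far as these compounds go, it remains open whether a methoxy group or an amine in place of the added hydroxy would also differ between the two cores.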